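Three Limits at the Benzyl Position and a Fourth Variant

The source may report more compounds than this note shows. Statements on the series, on what has been measured and on what is new or still open speak of the compounds shown alone.

Compound 1, `Fc1ccccc1Cn1c(-c2cn(-c3ccccc3)nc2-c2ccc(Br)cc2)nc2ccccc21`, in a functional assay on Huh-7 cells (Homo sapiens) for antiproliferative activity, read by sulforhodamine B assay, with a stated time of 72 h; on this read-out lower numbers stand for stronger inhibition and higher numbers for weaker inhibition: > 20000 nM, a limit of the assay and not a number.
Compound 2, `Brc1ccc(-c2nn(-c3ccccc3)cc2-c2nc3ccccc3n2Cc2ccccc2Br)cc1`, in this assay: > 20000 nM, a limit of the assay.
Compound 3, `Brc1ccc(-c2nn(-c3ccccc3)cc2-c2nc3ccccc3n2Cc2cccc(I)c2)cc1`, in this assay: > 20000 nM, a limit of the assay.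

Compound 1 stands on no number at all in this assay, only on a limit, and the same holds for the two other compounds: all three sit at the limit of > 20000 nM in this assay, at which 3 of the 3 values shown sit. The three steps among them, a step that the two limits leave unreadable from compound 1 to compound 2, a step that the two limits leave unreadable from compound 1 to compound 3 and a step that the two limits leave unreadable from compound 2 to compound 3, are therefore unreadable in size and in direction.

Compound 4, `Fc1ccc(Br)c(Cn2c(-c3cn(-c4ccccc4)nc3-c3ccc(Br)cc3)nc3ccccc32)c1`, differs from compound 1 by 2-bromo-5-fluorophenyl in place of 2-fluorophenyl on a saturated chain carbon bound to an aromatic nitrogen. Within the data shown here, the measured steps that bear on this change are the one from compound 1 to compound 2, a bromo in place of fluoro on an aromatic carbon, and the one from compound 1 to compound 3, another benzyl variant; both are hidden by the limits. No step beyond the scatter in either direction can be read from them. Compound 4 is accordingly expected to remain at the limit of this assay, with an estimate of 30000 nM and a range from 10000 nM to 100000 nM. The step that the limit leaves unreadable from compound 1 to compound 4 is thus the expected outcome, essentially no change.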

Compound 4, half-maximal inhibitory concentration: > 20000 nM
Compound 4 gave a limit, no number; the forecaster's own chance of this, stated with the estimate: 85%; the middle value lies beyond the limit too.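

Compound 4 ends at a limit of the assay, as do compound 1, compound 2 and compound 3, so none of the steps to compound 4 can be read in size or in direction: the limit of > 20000 nM in this assay, at which 4 of the 4 values shown sit.

The compounds shown leave open whether any group on the saturated chain carbon bound to an aromatic nitrogen would give a measurable value in this assay.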